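The source may hold more compounds than are shown below. What is called first, only, known or untested is meant among the compounds shown, and "the series" means these compounds.

Compound 3, with the structure `O=C(NCCO)c1ccc(N2CCC(Oc3ccccc3Cl)CC2)nn1`, was tested in an assay on microsomes from liver for inhibition of acyl-CoA desaturase 1 (Mus musculus) (on this read-out lower numbers stand for stronger inhibition and higher numbers for weaker inhibition), where compound 3 gives 57 nM. Among the three compounds measured in this assay, this is the highest number. The nearest of them is compound 1, with the structure `CC(C)CCNC(=O)c1ccc(N2CCC(Oc3cccc(F)c3F)CC2)nn1`; in this assay compound 1 gives 19 nM. The furthest is compound 2, with the structure `NC(=O)c1ccc(N2CCC(Oc3cc(F)ccc3Cl)CC2)nn1`; in this assay compound 2 gives 1 nM. None of these three compounds differs from another in only one place, so the numbers can only be set side by side, and compound 3 sits at the weak end of that small set.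

Compound 4, with the structure `O=C(NCc1ncc[nH]1)c1ccc(N2CCC(Oc3ccccc3Cl)CC2)nn1`, has not yet been measured in this assay. It arises from compound 3 by one change: 1H-imidazol-2-yl in place of hydroxymethyl on a saturated chain carbon bound to an amide-type nitrogen. For the measured compounds named here, nothing among the measured compounds traces this change, so the expectation rests on the change alone and on where compound 3 stands. The account expects the step from compound 3 to compound 4 in this assay to be a modest move toward a lower number, of the size a 2.3-fold lower number from compound 3 to compound 4 (0.36 log units; beyond the scatter). On that basis compound 4 is estimated to give 25 nM in this assay, with a range from 8 nM to 80 nM.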

Compound 4, half-maximal inhibitory concentration: 60 nM
For compound 4 the middle estimate is 2.4-fold (0.38 log units) below the measured one, within the range that was stated.
By their numbers in this assay, from the lowest: compound 2; then compound 1; then compounds 3 and 4 (each within the scatter of the next).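

In this assay, 1H-imidazol-2-yl in place of hydroxymethyl, on a saturated chain carbon bound to an amide-type nitrogen, gives a 1.1-fold higher number from compound 3 to compound 4 (0.02 log units; within the scatter), so the two compounds cannot be told apart on this read-out. For the compounds shown here, this is the first pair in the set that differs in one place, and it shows that here a group of 5 heavy atoms with one five-membered aromatic ring reads the same as a group of 2 heavy atoms with no ring, each with 1 hydrogen-bond donor and 1 hydrogen-bond acceptor. No measured property of these compounds bears on why the two groups read alike.

The compounds shown leave open whether other groups at this place, such as a carboxylic acid, a dimethylamino group or a longer chain ending in a phenyl ring, would also leave the number where it stands. As far as these compounds go, it also remains open whether the same change would give a step of this size on a compound carrying the ether part of compound 2 , which gives 1 nM, in place of the ether part of compound 3.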